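Amide-side substituent changes on the shared core

A few compounds are considered here, and "the series" means these few. Any claim that something is new, unique, unknown or untested is made for them only; others in the source may bear on it.

Compound 2 `C=CC1=C(C(=O)NCCC)C(c2ccc(OC)c(OC)c2)OC1` stands only at a limit: in a functional assay on SW480 cells (Homo sapiens) for cytotoxicity, read by MTT assay, with a stated time of 24 h (a higher number here means a weaker inhibitor, a lower number a stronger inhibitor), compound 2 gives > 100000 nM, a limit of the assay rather than a number. Compound 1 `C=CC1=C(C(=O)NCc2ccccc2)C(c2ccc(OC)c(OC)c2)OC1` likewise gives > 100000 nM in this assay, again a limit. The step that the two limits leave unreadable from compound 1 to compound 2 is thus unreadable. Compound 3 `C=CC1=C(C(=O)NCc2ccc(C)cc2)C(c2ccc(OC)c(OC)c2)OC1` differs from compound 2 by 4-methylphenyl in place of ethyl on a saturated chain carbon bound to an amide-type nitrogen. Both measured values sit at the limit of > 100000 nM in this assay, at which 2 of the 2 values shown sit, so no direction can be read for this change. Compound 3 is expected to give 150000 nM (range 50000 nM to 500000 nM), most likely once more as a limit. The expected step that the limit leaves unreadable from compound 2 to compound 3 is therefore not beyond the scatter.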

Compound 3, half-maximal inhibitory concentration: > 100000 nM
Compound 3: a limit, no number; the forecaster's own chance of this, stated with the estimate: 85%; the middle value does not contradict the limit.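

In this assay compound 3 gives > 100000 nM, a limit and not a number. Within the data shown here, no step among compound 1, compound 2 and compound 3 can be read. The compounds shown leave open whether any amide-side substituent on the shared core gives a measurable value.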